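Acetyl to 2-hydroxyethyl on the shared core

The source may report more compounds than this note shows. Statements on the series, on what has been measured and on what is new or still open speak of the compounds shown alone.

In a functional assay on HL-60 cells (Homo sapiens) for cytotoxicity, read by MTT assay, with a stated time of 24 h (a lower number here means a stronger inhibitor, a higher number a weaker inhibitor), compound 1 `CC(=O)Oc1c(Br)cc(Br)cc1Oc1ccc(Br)cc1Br` reads 29.9 ug/mL and compound 2 `CC(C)(C)OC(=O)N1CCN(CCCCCOc2c(Br)cc(Br)cc2Oc2ccc(Br)cc2Br)CC1` reads 32.1 ug/mL while compound 3 `Brc1ccc(Oc2cc(Br)cc(Br)c2OCCCCCN2CCN(C/C=C/c3ccccc3)CC2)c(Br)c1` reads 47.2 ug/mL so compound 1 stands within the scatter of compound 2 and of compound 3.

Compound 4 `OCCOc1c(Br)cc(Br)cc1Oc1ccc(Br)cc1Br` keeps the core of compound 1 and carries 2-hydroxyethyl in place of acetyl on an oxygen on an aromatic ring. The same difference reads as acetoxy to 2-hydroxyethoxy.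

Among the measured compounds shown here, no measured step covers this change directly. For the measured compounds named here, the only single-place step is a 1.5-fold higher number from compound 2 to compound 3 (0.17 log units; within the scatter) and it lies within the scatter, but it concerns an amine nitrogen in a ring and not the oxygen. Closer to the point, compound 2 at 32.1 ug/mL and compound 3 at 47.2 ug/mL carry other groups on that oxygen and still lie within the scatter of compound 1. On these few compounds, no step beyond the scatter is expected in this assay and no direction can be assigned. The estimated step is a 1.1-fold higher number from compound 1 to compound 4 (0.04 log units; within the scatter) and it remains an expectation only. In this assay the estimate for compound 4 is 33 ug/mL with 17 ug/mL to 62 ug/mL as the expected range.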

Compound 4, half-maximal inhibitory concentration: 28.2 ug/mL
Beside the measured number, compound 4's estimate is 1.2-fold (0.07 log units) above it, within the range that was stated.
By their numbers in this assay, from the lowest: compounds 4, 1, 2 and 3 (each within the scatter of the next).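

In this assay, among the compounds shown here, a 1.1-fold lower number from compound 1 to compound 4 (0.03 log units; within the scatter), which gives the first single-place reading at this oxygen on an aromatic ring. Acetoxy to 2-hydroxyethoxy removes the double bond outside aromatic rings and brings in the hydrogen-bond donor of 2-hydroxyethyl while the heavy-atom count stays the same, yet this assay does not separate the two compounds, so on this one pair the exchange leaves the read-out inside the scatter and gives it no direction. Nothing measured here bears on why the two compounds read alike.

Going by these compounds, what remains open is whether a group of another kind on this oxygen, such as a primary amine, a carboxylic acid or a longer chain ending in hydroxyl, would give a step beyond the scatter from compound 1 in this assay. The compounds shown also leave open whether 2-hydroxyethyl would read the same way on a different core, and whether the free hydroxyl of 2-hydroxyethyl matters at all, since a plain ethyl group on this oxygen is not among them.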